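This account rests on a few compounds, and the source may have more. Where it says the series, first, only, none or still open, it means among the compounds named here.

Compound 1 `C/C(=N\NC(=O)c1cccc(S(=O)(=O)N2CCOCC2)c1)c1ccccc1O` and compound 2 `C/C(=N\NC(=O)c1cccc(S(=O)(=O)N2CCOCC2)c1)c1cc(Br)ccc1O` share a core, and compound 3 `O=C(N/N=C/c1cc(Br)ccc1O)c1cccc(S(=O)(=O)N2CCOCC2)c1` carries a core whose difference from that of compound 1 is not broken down here. In a functional assay on ECa-109 cells for antiproliferative activity against ECa-109 cell line (Homo sapiens), read by MTT assay, with a stated time of 72 h (on this read-out lower numbers stand for stronger inhibition and higher numbers for weaker inhibition), compound 1 gives 5450 nM, compound 2 gives 5280 nM and compound 3 gives 11700 nM. The change from compound 1 to compound 2 is bromo in place of hydrogen on an aromatic carbon, and it made a 1.0-fold lower number from compound 1 to compound 2 (0.01 log units; within the scatter). Compound 4 `O=C(N/N=C/c1cc(Br)cc(Br)c1O)c1cccc(S(=O)(=O)N2CCOCC2)c1` arises from compound 3 by the same kind of change, (bromo in place of hydrogen on an aromatic carbon), though here the entering group sits ortho to a hydroxy group and meta to a bromo group rather than para to a hydroxy group. Because a 1.0-fold lower number from compound 1 to compound 2 (0.01 log units; within the scatter) was flat, compound 4 is expected to give 10000 nM in this assay, a step of a 1.2-fold lower number from compound 3 to compound 4 (0.07 log units; within the scatter), with the range 4000 nM to 25000 nM.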

Compound 4, half-maximal inhibitory concentration: 10300 nM
The estimate for compound 4 lay 1.0-fold (0.01 log units) below the measured number, within the range that was stated.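

In this assay, bromo in place of hydrogen on an aromatic carbon was as flat on the core of compound 3 as on the core of compound 1, with a 1.1-fold lower number from compound 3 to compound 4 (0.06 log units; within the scatter). The change therefore carried from one core to the other without a detectable difference in the size of its step: the same change on two cores in this assay, a 1.0-fold lower number (0.01 log units; within the scatter) from compound 1 to compound 2 and a 1.1-fold lower number (0.06 log units; within the scatter) from compound 3 to compound 4, 1.1-fold (0.04 log units) apart, within the scatter of two such steps. Within the data shown here, this rests on only two pairs, with the entering group placed differently in each, and it does not show that the step would stay flat on any other core or at any other place.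

The compounds shown leave open whether an amine, a carboxylic acid or a longer chain on that aromatic carbon would give a step beyond the scatter. They also leave open what a methoxy group in place of the hydroxy group would do.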